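Carboxymethyl gives way to 1H-benzimidazol-6-yl on an amide nitrogen

A few compounds are considered here, and "the series" means these few. Any claim that something is new, unique, unknown or untested is made for them only; others in the source may bear on it.

In a functional assay on CLL cells (Homo sapiens) for cytotoxicity, read by MTT assay, with a stated time of 48 h (a higher number here means that more compound is needed for the effect, a lower number that less compound is needed), compound 1 (`C=C(CC)C(=O)c1ccc(OCC(=O)NCC(=O)O)c(Cl)c1Cl`) gives > 25000 nM, which is a limit of the assay and not a number. Two relatives carry an aromatic ring rather than carboxymethyl on the amide-type nitrogen. Compound 2 (`C=C(CC)C(=O)c1ccc(OCC(=O)Nc2ccc3cc(C(=O)O)ccc3c2)c(Cl)c1Cl`) gives 3700 nM and compound 3 (`C=C(CC)C(=O)c1ccc(OCC(=O)Nc2ccc(C(=O)NC(CCC(=O)OCC)C(=O)OCC)cc2)c(Cl)c1Cl`) gives 2100 nM, two values within the usual scatter of each other.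

Compound 4 (`C=C(CC)C(=O)c1ccc(OCC(=O)Nc2ccc3nc[nH]c3c2)c(Cl)c1Cl`) has 1H-benzimidazol-6-yl in place of carboxymethyl on an amide-type nitrogen, and the counted change is 1H-benzimidazol-6-yl in place of carboxymethyl on an amide-type nitrogen. Within the data shown here, no measured pair isolates this change, so its size can only be inferred from the neighbouring compounds. In this assay a step beyond the scatter is expected, towards less compound being needed. That expectation rests on compound 2 with 3700 nM and compound 3 with 2100 nM. The estimated step is an at least 6.2-fold lower number from compound 1 to compound 4 (0.79 log units; beyond the scatter). Compound 4 is expected at 4000 nM, with an estimated range of 1500 nM to 12000 nM.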

Compound 4, half-maximal effective concentration: 3200 nM
Estimate against measurement, compound 4: 1.3-fold (0.10 log units) above; measured number inside the range.
By their numbers in this assay, from the lowest: compounds 3, 4 and 2 (each within the scatter of the next). At a limit, above all of these: compound 1.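

Among these compounds, for the first time, a single change on the amide-type nitrogen can be read directly in this assay: 1H-benzimidazol-6-yl in place of carboxymethyl gives an at least 7.8-fold lower number from compound 1 to compound 4 (0.89 log units; beyond the scatter). Compound 1 stands at > 25000 nM, which is a limit of the assay and not a number, so this step gives only a lower bound on the true size of the change: the limit of > 25000 nM in this assay, at which 1 of the 4 values shown sits. The entering 1H-benzimidazol-6-yl carries no carboxylic acid, so a measured number at this position does not require one.

The compounds shown leave open whether the ring nitrogens of compound 4 matter, or whether an unsubstituted phenyl on this nitrogen would read the same. They also leave open how a longer chain ending in a carboxylic acid would read in place of carboxymethyl.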